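One More Carbon in the Ester Chain of Compound 3

This account rests on a few compounds, and the source may have more. Where it says the series, first, only, none or still open, it means among the compounds named here.

Three compounds share a core with a urea-linked chlorophenyl group, a primary carboxamide and a ring nitrogen carrying a chain that ends in a tert-butyl ester. Compound 1 `CC(C)(C)OC(=O)CCCN1CCc2c(sc(NC(=O)Nc3ccc(Cl)cc3)c2C(N)=O)C1` bears that chain on a neutral ring nitrogen; in a functional assay (strain AB) with Danio rerio as the target, read by microscopy, with a stated time of 1 h (on this read-out lower numbers stand for an effect already at smaller amounts and higher numbers for an effect only at larger amounts of compound), compound 1 gives 560 nM. Compound 2 `CC(C)(C)OC(=O)CCC[N+]1(C)CCc2c(sc(NC(=O)Nc3ccc(Cl)cc3)c2C(N)=O)C1` adds a methyl to the ring nitrogen, which then carries a positive charge, and compound 2 gives 250 nM. Compound 3 `CC(C)(C)OC(=O)CCCC[N+]1(C)CCc2c(sc(NC(=O)Nc3ccc(Cl)cc3)c2C(N)=O)C1` lengthens the ester chain by one carbon, and compound 3 gives 140 nM. On these numbers compound 3 stands lowest of the three: compound 2 is its nearest neighbour, within the scatter, while compound 1 is furthest away, beyond the scatter. Going by the values given here, the one measured step of this kind, a 1.8-fold lower number from compound 2 to compound 3 (0.25 log units; within the scatter), is small.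

Compound 4 `CC(C)(C)OC(=O)CCCCC[N+]1(C)CCc2c(sc(NC(=O)Nc3ccc(Cl)cc3)c2C(N)=O)C1` carries the same change once more: (tert-butoxycarbonyl)methyl in place of tert-butoxycarbonyl on a saturated chain carbon, four bonds along the chain from an amine nitrogen in a ring. The step that bears on it is a 1.8-fold lower number from compound 2 to compound 3 (0.25 log units; within the scatter), and since that step stayed within the scatter, a similarly small movement, or none, is expected for compound 4. Compound 4 is therefore estimated to give 110 nM, in the range 50 nM to 250 nM. The expected step of a 1.3-fold lower number from compound 3 to compound 4 (0.10 log units; within the scatter) would lie within the scatter.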

Compound 4, half-maximal effective concentration: 110 nM
Compound 4: middle estimate and measured number agree at the digits printed; the range from low to high includes it.
By their numbers in this assay, from the lowest: compounds 4, 3 and 2 (each within the scatter of the next, the first and the last beyond it); then compound 1.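

In this assay the further lengthening gives a 1.3-fold lower number from compound 3 to compound 4 (0.10 log units; within the scatter) and so does not separate compound 4 from compound 3 at this place, on a saturated chain carbon, four bonds along the chain from an amine nitrogen in a ring. Over the longer stretch, 2-(tert-butoxycarbonyl)ethyl in place of tert-butoxycarbonyl gives a 2.3-fold lower number from compound 2 to compound 4 (0.36 log units; beyond the scatter) and is the first comparison of chain length among these compounds to pass beyond the scatter, although only modestly, so a difference appears here only across the two single-carbon steps taken together, neither of which stands out from the scatter alone. Nothing measured on these compounds accounts for this difference in chain length.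

The compounds shown leave open whether a longer chain than the 4-(tert-butoxycarbonyl)butyl of compound 4 would keep the number where it stands or move it, and whether a carboxylic acid in place of the tert-butyl ester would change the read-out at any of these chain lengths. They also leave open whether the same lengthening would act alike on a ring nitrogen without the added methyl, as in compound 1.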